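This account rests on a few compounds, and the source may have more. Where it says the series, first, only, none or still open, it means among the compounds named here.

In a functional assay on A549 cells (Homo sapiens) for antiproliferative activity, read by MTT assay, with a stated time of 48 h (on this read-out lower numbers stand for stronger inhibition and higher numbers for weaker inhibition), three compounds built on one shared core have been measured. Compound 1 `COc1ccc(Nc2ccc3c(c2)C(O)(Cc2ccccc2)C(=O)N3)cc1` reports only a limit, > 30000 nM. Compound 2 `O=C1Nc2ccc(Nc3ccc(F)cc3)cc2C1(O)Cc1ccccc1` gives 3000 nM. Compound 3 `CC(C)CCC1(O)C(=O)Nc2ccc(Nc3ccc(Cl)cc3)cc21` gives 2700 nM, which lies within the scatter of the value for compound 2. The move to compound 4 `O=C1Nc2ccc(Nc3ccc(Cl)cc3)cc2C1(O)Cc1ccccc1` is phenyl in place of isobutyl on a saturated chain carbon bound to a saturated ring carbon, or isopentyl to benzyl when cut one bond further out. Going by the values given here, the only measured step, an at least 10-fold lower number from compound 1 to compound 2 (1.00 log units; beyond the scatter), is fluoro in place of methoxy on an aromatic carbon. It does not touch the place of the present change, so it bears on this move only indirectly. Compound 2, at 3000 nM, already carries the benzyl that enters here, so no step beyond the scatter is expected in this assay. The expected step is a 1.1-fold lower number from compound 3 to compound 4 (0.03 log units; within the scatter). Compound 4 is estimated at 2500 nM, with an expected range of 1000 nM to 6500 nM.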

Compound 4, half-maximal inhibitory concentration: 3100 nM
For compound 4 the middle estimate is 1.2-fold (0.09 log units) below the measured one; the range from low to high includes it.
By their numbers in this assay, from the lowest: compounds 3, 2 and 4 (each within the scatter of the next). At a limit, above all of these: compound 1.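

In this assay, phenyl in place of isobutyl on a saturated chain carbon bound to a saturated ring carbon gives a 1.1-fold higher number from compound 3 to compound 4 (0.06 log units; within the scatter), so at this place isopentyl and benzyl cannot be told apart by this read-out, at least with chloro on the aromatic carbon. Chloro in place of fluoro on an aromatic carbon gives a 1.0-fold higher number from compound 2 to compound 4 (0.01 log units; within the scatter), whereas chloro in place of methoxy gives an at least 9.6-fold lower number from compound 1 to compound 4 (0.98 log units; beyond the scatter), so the step away from methoxy holds for chloro as it does for fluoro. The value of compound 1 is a limit, not a number: the limit of > 30000 nM in this assay, at which 1 of the 4 values shown sits.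

Still open, from the compounds shown here alone, is whether an amine, a carboxylic acid or a longer chain at this saturated chain carbon would shift the number. Also open, going by these compounds, is how a nitrile or a trifluoromethyl on the aromatic carbon would compare with chloro and fluoro.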